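This account rests on a few compounds, and the source may have more. Where it says the series, first, only, none or still open, it means among the compounds named here.

The set of compounds shares one core and differs only in the aryl group attached through the triple bond. Compound 1 `O=C1c2ccc(C#Cc3ccccc3)nc2CCN1C1CCCC1` carries an unsubstituted phenyl and in a functional assay on HEK293 cells for positive allosteric modulation of metabotropic glutamate receptor 5 (Homo sapiens), read by FLIPR and calcium flux (a higher number here means that more compound is needed for the effect, a lower number that less compound is needed), compound 1 gives 5.9 nM. Compound 2 `Cc1ccc(C#Cc2ccc3c(n2)CCN(C2CCCC2)C3=O)cc1` carries a 4-methylphenyl and in this assay compound 2 gives 4820 nM. Compound 3 `O=C1c2ccc(C#Cc3cccc(Cl)c3)nc2CCN1C1CCCC1` carries a 3-chlorophenyl and in this assay compound 3 gives 33 nM, which places it second highest of the three numbers, with compound 1 nearest and compound 2 furthest.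

The steps among the measured compounds are uneven in size: an 820-fold higher number from compound 1 to compound 2 (2.91 log units; beyond the scatter) and a 150-fold lower number from compound 2 to compound 3 (2.16 log units; beyond the scatter) are both large, whereas a 5.6-fold higher number from compound 1 to compound 3 (0.75 log units; beyond the scatter) is only modest. Compound 4 `COc1cccc(C#Cc2ccc3c(n2)CCN(C2CCCC2)C3=O)c1` differs from compound 3 by methoxy in place of chloro on an aromatic carbon, so the 3-chlorophenyl becomes a 3-methoxyphenyl. Going by the values given here, the only direct guidance for a change at this position is the modest step from compound 1 to compound 3, since a group meta to the large group cost much less than the methyl of compound 2 did. The step in this assay from compound 3 to compound 4 is therefore expected to be small, perhaps a slight rise, as a 1.5-fold higher number from compound 3 to compound 4 (0.18 log units; within the scatter) shows. Compound 4 is estimated to give about 50 nM, within a range from 10 nM to 300 nM.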

Compound 4, half-maximal effective concentration: 462 nM
Compound 4: the middle estimate sits 9.2-fold (0.97 log units) below what was measured, outside the stated range (above it).
By their numbers in this assay, from the lowest: compound 1; then compound 3; then compound 4; then compound 2.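

In this assay, the aromatic carbon meta to a large group proves far less tolerant than the chloro compound suggested: the change from chloro to methoxy gives a 14-fold higher number from compound 3 to compound 4 (1.15 log units; beyond the scatter) and so exceeds the modest cost of chloro, which was a 5.6-fold higher number from compound 1 to compound 3 (0.75 log units; beyond the scatter) in this assay. Set against the unsubstituted phenyl, the methoxy group gives a 78-fold higher number from compound 1 to compound 4 (1.89 log units; beyond the scatter) and the 3-methoxyphenyl still keeps some ground over the 4-methylphenyl with a 10-fold lower number from compound 2 to compound 4 (1.02 log units; beyond the scatter) so that all three substituted compounds have higher numbers than compound 1, though by very different amounts. Nothing available here accounts for the large gap between chloro and methoxy at this place.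

From the compounds shown here alone, it remains open whether fluoro, methyl or a nitrile at this same carbon would fall nearer to chloro or to methoxy, and whether a hydroxyl or an amine would cost more still. Compound 2 differs from compound 3 and compound 4 in both group and place. A 3-methylphenyl or a 4-chlorophenyl would be needed to tell how much of its high number belongs to the methyl and how much to its position.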